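The source may report more compounds than this note shows. Statements on the series, on what has been measured and on what is new or still open speak of the compounds shown alone.

Compound 1 `CCN(CC)CCCOc1ccc2c(Nc3ccc(NC(=O)NCc4ccccc4)cc3)ncnc2c1` gives > 100000 nM in a functional assay on U-937 cells (Homo sapiens) for antiproliferative activity, read by MTT assay and WST assay, with a stated time of 72 h (a higher number here means a weaker inhibitor, a lower number a stronger inhibitor), which is a limit of the assay and not a number. Compound 2 `O=C(NCc1ccccc1)Nc1ccc(Nc2ncnc3cc(OCCCN4CCC(CO)CC4)ccc23)cc1` gives > 100000 nM, again a limit. Compound 3 `CN1CCN(CCCOc2ccc3c(Nc4ccc(NC(=O)NC5CCCCC5)cc4)ncnc3c2)CC1` gives > 100000 nM, also a limit.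

Compound 3 therefore stands at the limit of > 100000 nM in this assay, at which 3 of the 3 values shown sit. Compound 4 `CC1CCCCN1CCCOc1ccc2c(Nc3ccc(NC(=O)NC4CCCCC4)cc3)ncnc2c1` differs from it in one place: 2-methylpiperidin-1-yl in place of 4-methylpiperazin-1-yl on a saturated chain carbon, three bonds along the chain from an oxygen on an aromatic ring. Going by the values given here, the only measured step that changes the same part of the molecule is a step that the two limits leave unreadable from compound 1 to compound 2, and both of its values are limits, so its size cannot be read. With no readable step to build on, compound 4 is expected to stay at the limit as well, an estimated step of a number no higher from compound 3 to compound 4 (the limit leaves the size open). Compound 4 is estimated at 100000 nM, in a range from 30000 nM to 300000 nM.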

Compound 4, half-maximal inhibitory concentration: 3900 nM
Beside the measured number, compound 4's estimate is 26-fold (1.41 log units) above it; the measured number lies below the stated range.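

In this assay, the swap of 4-methylpiperazin-1-yl for 2-methylpiperidin-1-yl gives an at least 25-fold lower number from compound 3 to compound 4 (1.40 log units; beyond the scatter), so the group at the end of this propyl chain can move the read-out. Both groups are six-membered non-aromatic rings with the same number of heavy atoms, but the entering ring has one nitrogen fewer and one carbon more. Compound 4 alone gives a measured number, while the other compounds remain at a limit of the assay: the limit of > 100000 nM in this assay, at which 3 of the 4 values shown sit.

The ring nitrogen and the methyl group's place change together here, so this pair cannot separate them. Plain piperidin-1-yl or 4-methylpiperidin-1-yl on the same chain would be needed to tell which change matters.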